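A few compounds are considered here, and "the series" means these few. Any claim that something is new, unique, unknown or untested is made for them only; others in the source may bear on it.

Compound 1, `Cc1cc(OCc2ccccc2)c2nc(C)c(N)n2c1`: 50%
Compound 2, `Cc1nc2c(OCc3ccccc3)cccn2c1CN`: 9%

In a functional assay on the whole organism with Canis familiaris (Canis lupus familiaris) as the target, at a dose of 8 mg/kg by the oral route (on this read-out lower numbers stand for a weaker effect and higher numbers for a stronger effect at the one dose given), compound 2 stands lowest of the two numbers; the nearest is compound 1, whose value lies higher by a margin beyond the usual scatter. Compound 3, `Cc1nc2c(OCc3ccccc3)cccn2c1/N=C/N(C)C`, has not been measured. The change from compound 2 to compound 3 is a group of 5 heavy atoms (3 carbon, 2 nitrogen; no ring) in place of a group of 2 heavy atoms (1 carbon, 1 nitrogen; no ring), on an aromatic carbon. Among the measured compounds shown here, no measured pair shows this change, so its effect in this assay is unknown; a step of modest size in either direction, or none beyond the scatter, is expected. Compound 3 is estimated at 15%, with a range of 0% to 45%. The step this estimate means, a number 6 percentage points higher from compound 2 to compound 3 (within the scatter), is expected to stay within the scatter.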

Compound 3, a percentage reported as inhibition, in the whole organism at one dose (the size of the read-out at that dose, not a potency): 0%
The estimate for compound 3 lay 15 percentage points above the measured number; the range from low to high includes it.
By their numbers in this assay, from the lowest: compounds 3 and 2 (each within the scatter of the next); then compound 1.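

At this aromatic carbon, the aminomethyl group gives way to a larger group with no hydrogen-bond donor, and the read-out in this assay shows a number 9 percentage points lower from compound 2 to compound 3 (within the scatter), so this exchange brings no step beyond the scatter. With both compounds on the same core, the added heavy atoms and the double bond outside the rings leave the read-out without a separable change. Nothing available bears on why this step is small.

Still open, as far as these compounds go, is how an aminoethyl chain or a carboxylic acid on this same carbon would read out in this assay.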